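The source may hold more compounds than are shown below. What is called first, only, known or untested is meant among the compounds shown, and "the series" means these compounds.

Working notes on the series. Among the compounds with values here, compound 1 `O=C(Nc1ccc(Oc2ccnc3[nH]ccc23)cc1)c1cc2cccnc2n(-c2ccc(C(F)(F)F)cc2Cl)c1=O` is the only member with a number in a functional assay on U-87MG ATCC cells for antiproliferative activity against U-87 MG (Homo sapiens), read by MTT assay, with a stated time of 72 h; a lower number here means a stronger inhibitor, a higher number a weaker inhibitor: in this assay compound 1 gives 6030 nM. Compound 2 `COc1ccc(-n2c(=O)c(C(=O)Nc3ccc(Oc4ccnc5[nH]ccc45)c(F)c3)cc3cccnc32)cc1` carries no result in this assay: for compound 2 the entry reads "not determined" (no result reported). Compound 3 `O=C(Nc1ccc(Oc2ccnc3[nH]ccc23)c(F)c1)c1cc2cccnc2n(-c2ccc(C(F)(F)F)cc2Cl)c1=O` likewise carries no result in this assay, the entry for compound 3 reading "not determined" (no result reported), so compound 3 stands without a number of its own and with no measured neighbour differing in one place; it is one of two entries in the set without a single value. Compound 4 `Cn1ccc2c(Oc3ccc(NC(=O)c4cc5cccnc5n(-c5ccc(C(F)(F)F)cc5Cl)c4=O)cc3F)ccnc21` is not yet measured in this assay. Between compound 3 and compound 4 the difference is methyl in place of hydrogen on an aromatic nitrogen of the five-membered ring of the fused two-ring system. Within the data shown here, no measured pair shows the effect of this change in this assay, so the size of the step rests on expectation only. The expectation is a weakening beyond the usual scatter, with the number for compound 4 in this assay estimated at 12000 nM and a range from 3000 nM to 50000 nM.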

Compound 4, half-maximal inhibitory concentration: 10200 nM
Compound 4: the middle estimate sits 1.2-fold (0.07 log units) above what was measured; the measured number falls inside the stated range.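

The step from compound 3 to compound 4 cannot be read in this assay, as the entry for compound 3 holds no single number. The compounds shown leave open what methyl in place of hydrogen on the aromatic nitrogen does in this assay. No supporting evidence bears on this result.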